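Chloro Added to Two Hydrazone and Thiosemicarbazide Analogues

A few compounds are considered here, and "the series" means these few. Any claim that something is new, unique, unknown or untested is made for them only; others in the source may bear on it.

Three compounds built on a shared thiol-bearing core were measured in a functional assay, with a stated time of 30 min; a higher number here means a weaker inhibitor, a lower number a stronger inhibitor. Compound 2 `Sc1nnc(-c2cnccn2)n1/N=C/c1ccc(Cl)cc1` gave 39800 nM in this assay. Compound 1 `Sc1nnc(-c2cnccn2)n1/N=C/c1ccc(Cl)cc1Cl` carries one change against compound 2, namely (chloro in place of hydrogen on an aromatic carbon). In this assay compound 1 gave 81200 nM. The result was a 2.0-fold higher number from compound 2 to compound 1 (0.31 log units; beyond the scatter). Compound 3 `S=C(Nc1ccc(Cl)cc1)Nn1c(S)nnc1-c1cnccn1` has a different core; how the two cores differ is not broken down here. In this assay compound 3 gave 75900 nM, a number within the scatter of compound 1 and of compound 2, so no order among the three can be drawn from it.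

Compound 4 `S=C(Nc1ccc(Cl)cc1Cl)Nn1c(S)nnc1-c1cnccn1` has not yet been measured. It stands to compound 3 as compound 1 stands to compound 2: the difference is chloro in place of hydrogen on an aromatic carbon, the same change at the same kind of place, here seen for the second time among these compounds. Among the measured compounds shown here, the only guide is the measured pair, where the number rose modestly. Because compound 3 already gave 75900 nM, the expected outcome is a still weaker inhibitor, and the step is expected to be a 1.8-fold higher number from compound 3 to compound 4 (0.27 log units; within the scatter). Compound 4 is thus estimated at 140000 nM in this assay, with a range from 60000 nM to 330000 nM; a number this high may fall beyond what the assay can report as a value.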

Compound 4, half-maximal inhibitory concentration: 58900 nM
The estimate for compound 4 lay 2.4-fold (0.38 log units) above the measured number; the measured number lies below the stated range.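

In this assay, among the compounds shown here, the change from 4-chlorophenyl to 2,4-dichlorophenyl on the core of compound 3 gave a 1.3-fold lower number from compound 3 to compound 4 (0.11 log units; within the scatter), so on this core the added chloro produced no step that can be told apart from the scatter. Set beside the pair on the core of compound 1, the two results do not separate: the same change on two cores in this assay, a 2.0-fold higher number (0.31 log units; beyond the scatter) from compound 2 to compound 1 and a 1.3-fold lower number (0.11 log units; within the scatter) from compound 3 to compound 4, 2.6-fold (0.42 log units) apart, within the scatter of two such steps. For the compounds shown here, this shows that these pairs give no firm ground for saying that the core alters the effect of the chloro, but it does not show that the change acts alike on both cores, and the step from the core of compound 1 cannot be carried over as a rule when each core offers only a single pair.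

The compounds shown carry only hydrogen or chloro at the changed place, so it remains open whether a methoxy group, a nitrile or an amine there would give a clearly different number on either core. All the numbers also come from this assay, which leaves open how the two pairs would read under a different read-out.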